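Bromo for chloro on a barely active compound

The compounds below may be only part of what the source reports. "The series", "measured", "known", "first", "only" and "open" are said of these compounds alone.

In a functional assay on Bel-7402 cells (Homo sapiens) for inhibition, read by MTT assay, with a stated time of 24 h, tested at 1 ug/mL (on this read-out higher numbers stand for more inhibition of growth at the one concentration tested and lower numbers for less inhibition of growth), compound 3 (`O=C(CCCCC(S)CCS)Nc1ccc(Cl)cn1`) gives 2.34% as the lower of the two numbers available. Compound 1 (`O=C(CCCCC1CCSS1)Nc1ccc(Br)cn1`) gives 13.1% and stands higher by more than the usual scatter. Compound 2 (`O=C(CCCCC(S)CCS)Nc1ccccn1`) comes out as "not active" (no number reported) and adds no figure. Compound 4 (`O=C(CCCCC(S)CCS)Nc1ccc(Br)cn1`) departs from compound 3 through bromo in place of chloro on an aromatic carbon and nothing else: bromo in place of chloro on an aromatic carbon. Among the compounds with values here, no measured pair shows this swap, so the data offer no direct guide to its size. The expected step of a number 3.7 percentage points higher from compound 3 to compound 4 (within the scatter) is small and upward, within the scatter. In this assay the estimate for compound 4 is 6% with an expected range from 0% to 16% around it.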

Compound 4, percent growth inhibition at one concentration: 4.71%
Compound 4: middle estimate off by 1.3 percentage points, on the high side; low and high end bracket the measured number.
By their numbers in this assay, from the lowest: compounds 3, 4 and 1 (each within the scatter of the next, the first and the last beyond it).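

In this assay, bromo in place of chloro on an aromatic carbon gives a number 2.4 percentage points higher from compound 3 to compound 4 (within the scatter), so the two halogens cannot be told apart at this position. The open chain in place of the five-membered ring gives a number 8.4 percentage points lower from compound 1 to compound 4 (within the scatter) and is likewise not separated from the scatter. No measurement shown offers an explanation for either step.

As far as these compounds go, whether an amine or a methoxy group at this position would shift growth inhibition beyond the scatter remains open. So does the effect of a longer chain.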